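The compounds below may be only part of what the source reports. "The series", "measured", "known", "first", "only" and "open" are said of these compounds alone.

Measured so far in an assay on isolated protein for inhibition of protein deacetylase HDAC6 (Homo sapiens), read by fluorescence; a higher number here means a weaker inhibitor, a lower number a stronger inhibitor:
compound 1 `Cn1cc(-c2ccccc2Oc2ccccc2)c2cc(C(=O)NCCCCCCC(=O)NO)[nH]c2c1=O` gives 4.7 nM
compound 2 `CC(C)Oc1ccc(C(C)(C)O)cc1-c1cn(C)c(=O)c2[nH]c(C(=O)NCCCCCCC(=O)NO)cc12` gives 5.4 nM

Compound 2 and compound 1 sit within the scatter of each other in this assay, so neither stands apart. Compound 3 `Cn1cc(-c2cc(C(C)(C)O)ccc2OC2CC2)c2cc(C(=O)NCCCCCCC(=O)NO)[nH]c2c1=O` is not yet measured. It differs from compound 2 by cyclopropyl in place of isopropyl on an oxygen on an aromatic ring, read one bond further out as isopropoxy to cyclopropyloxy. For the measured compounds named here, no measured pair shows this change, so no step beyond the scatter is expected in either direction. Compound 3 is estimated at 5.5 nM, within 2.5 nM to 12 nM. The expected step is a 1.0-fold higher number from compound 2 to compound 3 (0.01 log units; within the scatter).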

Compound 3, half-maximal inhibitory concentration: 5.5 nM
Estimate against measurement, compound 3: no gap at the digits printed; the measured number falls inside the stated range.
By their numbers in this assay, from the lowest: compounds 1, 2 and 3 (each within the scatter of the next).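

On the oxygen on the aromatic ring, cyclopropyl in place of isopropyl gives a 1.0-fold higher number from compound 2 to compound 3 (0.01 log units; within the scatter) in this assay. For the compounds shown here, this is the first single-place comparison: at this position, the ring-closed three-carbon group and the open one cannot be told apart in this assay. Nothing available explains this result.

Still open, going by these compounds, is whether a group of another kind on this oxygen, such as an amine, a carboxylic acid or a longer chain, would also leave the number within the scatter.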